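Swapping the Amide Tail: Expecting Compound 3

A few compounds are considered here, and "the series" means these few. Any claim that something is new, unique, unknown or untested is made for them only; others in the source may bear on it.

Compound 1: `COc1cc(-c2nn(-c3cccc(NC(=O)c4ccc(Cl)c(C(F)(F)F)c4)c3)cc2-c2ccncc2)ccc1Cl` — 11200 nM
Compound 2: `O=C(Nc1cccc(-n2cc(-c3ccncc3)c(-c3ccc(Cl)c(O)c3)n2)c1)Nc1ccc(Cl)c(C(F)(F)F)c1` — 1120 nM

Among the compounds with values here, in a functional assay on SN12C cells (Homo sapiens) for inhibition, read by sulforhodamine B assay, with a stated time of 48 h (on this read-out lower numbers stand for stronger inhibition of growth and higher numbers for weaker inhibition of growth), compound 1 gives 11200 nM, the highest of the two numbers measured so far. Compound 2 gives 1120 nM, a number lower by an amount well beyond the usual scatter. Compound 3 `COc1cc(-c2nn(-c3cccc(NC(=O)Nc4ccc(Cl)c(Cl)c4)c3)cc2-c2ccncc2)ccc1Cl` has not been measured yet. It differs from compound 1 in one place: (3,4-dichlorophenyl)amino in place of 4-chloro-3-(trifluoromethyl)phenyl on a carbonyl carbon. Within the data shown here, no measured pair shows this single change on its own, so the expected direction rests only on the fact that the one other number, that of compound 2, is lower. The expected step is estimated as a 2.8-fold lower number from compound 1 to compound 3 (0.45 log units; beyond the scatter), a moderate move toward a lower number. This rests on a single comparison, and the actual outcome may differ. For compound 3 the estimate in this assay is 4000 nM, in a range from 1000 nM to 16000 nM.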

Compound 3, concentration for 50% growth inhibition: 1470 nM
The estimate for compound 3 lay 2.7-fold (0.43 log units) above the measured number; the measured number falls inside the stated range.
By their numbers in this assay, from the lowest: compounds 2 and 3 (each within the scatter of the next); then compound 1.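

In this assay, placing (3,4-dichlorophenyl)amino on the carbonyl carbon instead of 4-chloro-3-(trifluoromethyl)phenyl gives a 7.6-fold lower number from compound 1 to compound 3 (0.88 log units; beyond the scatter), so the group at this position clearly affects the read-out on the core of compound 1. The swap changes two things at once: the entering group brings an amino nitrogen that carries a hydrogen-bond donor, and its ring has two chlorines rather than a chlorine and a trifluoromethyl. No measured property accounts for the step, so its cause remains unknown.

The compounds shown cannot say whether the amino nitrogen or the altered ring substituents produced the change. Also open, from the compounds shown here alone, is how a group with a different ring, such as cyclohexylamino, or a longer link, such as benzylamino, would read at this carbonyl carbon.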